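A few compounds are considered here, and "the series" means these few. Any claim that something is new, unique, unknown or untested is made for them only; others in the source may bear on it.

Measured in a functional assay for agonist activity at G protein-coupled receptor 88 (Homo sapiens), read by HTRF and cAMP accumulation; a lower number here means that less compound is needed, a higher number that more compound is needed for the effect:
compound 1, `CC(C)C[C@H](N)CN(C(=O)[C@@H]1C[C@H]1c1ccccc1)c1ccc(-c2ccccc2)cc1`: 880 nM
compound 2, `CC(C)C[C@@H](N)CN(C(=O)[C@@H]1C[C@H]1c1ccccc1)c1ccc(-c2ccccc2)cc1`: 1.8 nM
compound 3, `O=C([C@@H]1C[C@H]1c1ccccc1)N(CC1CCCNC1)c1ccc(-c2ccccc2)cc1`: 10 nM

Compound 1 gives the highest number of the three in this assay; its nearest neighbour is compound 3, its furthest compound 2. The change of configuration a 490-fold lower number from compound 1 to compound 2 (2.69 log units; beyond the scatter) is large, and the exchange of the amine side chain an 88-fold lower number from compound 1 to compound 3 (1.94 log units; beyond the scatter) is also large.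

Compound 4, `CC(C)C[C@H](N)CN(C(=O)[C@@H]1C[C@H]1c1ccccc1)c1ccc(C2=CCCCC2)cc1`, keeps everything of compound 1 except (cyclohex-1-en-1-yl in place of phenyl on an aromatic carbon). Among the measured compounds shown here, none of the measured steps touches this ring; all of them concern the other end of the core. No direction can be read from them, so in this assay no step beyond the scatter is expected, a 1.0-fold higher number from compound 1 to compound 4 (0.01 log units; within the scatter). Compound 4 is therefore estimated at 900 nM, within 250 nM to 3500 nM.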

Compound 4, half-maximal effective concentration: 1200 nM
Beside the measured number, compound 4's estimate is 1.3-fold (0.12 log units) below it, within the range that was stated.
By their numbers in this assay, from the lowest: compound 2; then compound 3; then compounds 1 and 4 (each within the scatter of the next).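

In this assay, cyclohex-1-en-1-yl in place of phenyl gives a 1.4-fold higher number from compound 1 to compound 4 (0.13 log units; within the scatter). Among the compounds shown here, at this place, para to a large group, a non-aromatic six-membered carbon ring therefore reads the same as the aromatic one, at least with the configuration of compound 1, the one with the high number. Nothing at hand gives a cause for this result.

On these data alone, whether the exchange reads the same with the configuration of compound 2 stays open. So does the outcome of a saturated cyclohexyl or a pyridyl ring at this place.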